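Taking the bromo off compound 2

The source may hold more compounds than are shown below. What is called first, only, known or untested is meant among the compounds shown, and "the series" means these compounds.

In a functional assay, with a stated time of 10 min (a lower number here means a stronger inhibitor, a higher number a weaker inhibitor), compound 1 `COc1cc(O)c(C(C)=O)cc1Br` gives 3000000 nM. Compound 2 `CCCCOc1cc(OC)c(Br)cc1C(C)=O` gives 56900000 nM and compound 3 `CCCCCCCCCCOc1cc(OC)c(Br)cc1C(C)=O` gives 29700000 nM. Compound 2 therefore lies well above compound 1 and within the scatter of compound 3. The measured steps are a 19-fold higher number from compound 1 to compound 2 (1.28 log units; beyond the scatter), which is large, and a 1.9-fold lower number from compound 2 to compound 3 (0.28 log units; within the scatter), which stays within the scatter. Both concern the chain on the oxygen, and the bromo is present in all three compounds. Compound 4 `CCCCOc1cc(OC)ccc1C(C)=O` keeps the butoxy group of compound 2 and differs by hydrogen in place of bromo on an aromatic carbon, para to a butoxy group. Neither measured step touches this position, so the data give no size or direction for the change. No step beyond the scatter is expected in this assay, though this expectation is loose. The estimated step is a 1.0-fold lower number from compound 2 to compound 4 (0.01 log units; within the scatter). The expected value for compound 4 is 55000000 nM, with an estimated range of 20000000 nM to 150000000 nM.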

Compound 4, half-maximal inhibitory concentration: 57200000 nM
Estimate against measurement, compound 4: 1.0-fold (0.02 log units) below; measured number inside the range.
By their numbers in this assay, from the lowest: compound 1; then compounds 3, 2 and 4 (each within the scatter of the next).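

In this assay, hydrogen in place of bromo on the aromatic carbon para to a butoxy group, ortho to a methoxy group and meta to an acetyl group, gives a 1.0-fold higher number from compound 2 to compound 4 (0.00 log units; within the scatter). Among the compounds shown here, this is the first reading at this position, and with the butoxy group in place the bromo makes no difference beyond the scatter, so the number stays as high as in compound 2. No measurement shown bears on why the number stays in place.

The compounds shown compare only bromo and hydrogen at this carbon, so an amine, a carboxylic acid or a nitrile there remains open. Also open, from the compounds shown here alone, is whether the same exchange holds with the free hydroxy group of compound 1 or the longer chain of compound 3.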